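A few compounds are considered here, and "the series" means these few. Any claim that something is new, unique, unknown or untested is made for them only; others in the source may bear on it.

In a functional assay on A549 cells (Homo sapiens) for cytotoxicity, read by MTT assay, with a stated time of 24 h (a higher number here means a weaker inhibitor, a lower number a stronger inhibitor), compound 1 `C#CCn1c(=O)c(C=O)cc2ccccc21` gives > 100000 nM as a limit of the assay and not as a number. Within the data shown here, compound 2 `C#CCn1c(=O)c(/C=C/C(=O)/C=C(O)/C=C/c2ccc(O)c(OC)c2)cc2ccccc21` gives 21300 nM and compound 3 `C#CCn1c(=O)c(/C=C/C(=O)/C=C(O)/C=C/c2ccc(O)c(OC)c2)cc2cc(OC)ccc21` gives 20600 nM in the same read-out, so compound 3 holds one of only two numbers and stands level with compound 2 within the scatter. Among the measured compounds shown here, the one measured step that bears on the next change is a 1.0-fold lower number from compound 2 to compound 3 (0.01 log units; within the scatter) for methoxy in place of hydrogen on an aromatic carbon, and it stays within the scatter. Compound 4 `C#CCn1c(=O)c(/C=C/C(=O)/C=C(O)/C=C/c2ccc(O)c(OC)c2)cc2cc(C)ccc21` has methyl in place of methoxy on an aromatic carbon, with the change counted as methyl in place of methoxy on an aromatic carbon and the rest of the structure the same. With compound 3 at 20600 nM and the step from hydrogen to methoxy within the scatter, no step beyond the scatter is expected in this assay when methyl takes the place of methoxy, and neither direction is favoured. The expected change is a 1.0-fold higher number from compound 3 to compound 4 (0.01 log units; within the scatter) and this is read as no real shift. Compound 4 is estimated at 21000 nM with 12000 nM to 38000 nM as the expected range.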

Compound 4, half-maximal inhibitory concentration: 23900 nM
Compound 4: middle estimate off by 1.1-fold (0.06 log units), on the low side, within the range that was stated.
By their numbers in this assay, from the lowest: compounds 3, 2 and 4 (each within the scatter of the next). At a limit, above all of these: compound 1.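

In this assay, this aromatic carbon of the fused system now carries three different groups across the compounds shown, namely hydrogen, methoxy and methyl, and the change of methoxy to methyl gives a 1.2-fold higher number from compound 3 to compound 4 (0.06 log units; within the scatter) with no real shift in the read-out. Set against hydrogen, methyl gives a 1.1-fold higher number from compound 2 to compound 4 (0.05 log units; within the scatter) and so stands level as well, which means the earlier step for methoxy is no longer the only substitution here that leaves the number in place, even though methyl brings no oxygen and no hydrogen-bond acceptor. Nothing in the data at hand explains why these three groups read alike at this position.

As far as these compounds go, whether the numbers stay level with a group of another kind at this position, such as an amine, a carboxylic acid, a chlorine atom or a longer chain like butoxy, remains open. Also open, from the compounds shown here alone, is whether any other aromatic carbon of the shared core tolerates change in the same way, or whether a substituent there would move the number beyond the scatter.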